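Swapping the Amide Aryl Group on an Acetamido Core

A few compounds are considered here, and "the series" means these few. Any claim that something is new, unique, unknown or untested is made for them only; others in the source may bear on it.

Of the compounds shown here, three have been measured in a functional assay on UACC-257 cells (Homo sapiens) for antiproliferative activity, read by sulforhodamine B assay, with a stated time of 48 h; a higher number here means a weaker inhibitor, a lower number a stronger inhibitor. Compound 1 `Nc1cccc2c(-c3cccc(NC(=O)c4ccc(Cl)c(C(F)(F)F)c4)c3)ccnc12` gives 2800 nM. Compound 2 `Nc1cccc2c(-c3cccc(NC(=O)c4nccs4)c3)ccnc12` gives 24300 nM. Compound 3 `COc1ccc(C(=O)Nc2cccc(-c3ccnc4c(NC(C)=O)cccc34)c2)cc1OC` gives 14200 nM, the second highest of the three numbers; its gap to compound 2 is within the scatter, while compound 1 lies beyond it. Compound 4 `CC(=O)Nc1cccc2c(-c3cccc(NC(=O)c4ccc(Cl)c(C(F)(F)F)c4)c3)ccnc12` has not yet been measured. It differs from compound 3 in one place: 4-chloro-3-(trifluoromethyl)phenyl in place of 3,4-dimethoxyphenyl on a carbonyl carbon. The step estimated here is a 3.2-fold lower number from compound 3 to compound 4 (0.50 log units; beyond the scatter) because compound 1 carrying the same 4-chloro-3-(trifluoromethyl)phenyl group on its carbonyl carbon gives 2800 nM. Compound 4 is therefore estimated at 4500 nM, with a range from 1800 nM to 12000 nM.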

Compound 4, half-maximal inhibitory concentration: 2700 nM
The estimate for compound 4 lay 1.7-fold (0.22 log units) above the measured number; the range from low to high includes it.
By their numbers in this assay, from the lowest: compounds 4 and 1 (each within the scatter of the next); then compounds 3 and 2 (each within the scatter of the next).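

In (this assay), 4-chloro-3-(trifluoromethyl)phenyl in place of 3,4-dimethoxyphenyl on a carbonyl carbon gives a change beyond the scatter on the acetylated core (a 5.3-fold lower number from compound 3 to compound 4 (0.72 log units; beyond the scatter)). Acetyl in place of hydrogen on a nitrogen on an aromatic ring stays within the scatter when the 4-chloro-3-(trifluoromethyl)phenyl group is present (a 1.0-fold lower number from compound 1 to compound 4 (0.02 log units; within the scatter)). No measurement shown explains either result.

Going by these compounds, it remains open whether a cyclohexyl or pyridine group on the carbonyl carbon would give a similar number. On these data alone, it is also open whether a longer chain than acetyl on that nitrogen would leave the number within the scatter.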